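The source may report more compounds than this note shows. Statements on the series, on what has been measured and on what is new or still open speak of the compounds shown alone.

Values so far in a functional assay on RAW264.7 cells (Mus musculus) for inhibition; a higher number here means a weaker inhibitor, a lower number a stronger inhibitor:
compound 1 (`COC(=O)C1=CCCCC1S(=O)(=O)Nc1ccc(F)cc1F`): 57 nM
compound 2 (`CCCOC(=O)C1=CCCCC1S(=O)(=O)Nc1ccc(F)cc1F`): 29 nM
compound 3 (`CC(C)OC(=O)C1=CCCCC1S(=O)(=O)Nc1ccc(F)cc1F`): not yet measured

Among the measured compounds shown here, compound 2 (29 nM) stands within the scatter of compound 1 (57 nM), the only other number available. The move to compound 3 puts isopropyl in place of propyl on an oxygen next to a carbonyl group. For the measured compounds named here, one measured step touches this chain (a 2.0-fold lower number from compound 1 to compound 2 (0.29 log units; within the scatter)), and since it stayed within the scatter, no step beyond the scatter is expected in this assay, in either direction. The expected step (a 1.1-fold higher number from compound 2 to compound 3 (0.04 log units; within the scatter)) therefore stays inside that scatter. For compound 3 the estimated value is 32 nM (expected range 12 nM to 80 nM).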

Compound 3, half-maximal inhibitory concentration: 110 nM
For compound 3 the middle estimate is 3.4-fold (0.54 log units) below the measured one; measured number above the stated range.
By their numbers in this assay, from the lowest: compounds 2, 1 and 3 (each within the scatter of the next, the first and the last beyond it).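

In this assay this position responds to how the chain is joined and not only to the atoms it holds: with propyl and isopropyl on the oxygen next to a carbonyl group, the result is a 3.8-fold higher number from compound 2 to compound 3 (0.58 log units; beyond the scatter) and this single change passes the scatter. Methyl to isopropyl gives a 1.9-fold higher number from compound 1 to compound 3 (0.29 log units; within the scatter) and so remains within it. Nothing available explains the gap between the two isomers.

Whether this gap is a general feature of branching rests on one pair. A butyl or tert-butyl ester, or the free carboxylic acid, would test how far it extends.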